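Aryl hydrazone variation on a nucleoside core

A few compounds are considered here, and "the series" means these few. Any claim that something is new, unique, unknown or untested is made for them only; others in the source may bear on it.

Compound 1, `COc1cc(/C=N/Nc2nc(N)c3ncn([C@@H]4O[C@H](CO)[C@@H](O)[C@H]4O)c3n2)cc(OC)c1OC`: 0%
Compound 2, `CCCOc1ccc(/C=N/Nc2nc(N)c3ncn([C@@H]4O[C@H](CO)[C@@H](O)[C@H]4O)c3n2)cc1`: 7%

Of the compounds shown here, two sharing one nucleoside core have been measured. In an assay on CHO-K1 cells for displacement of a labelled ligand from adenosine receptor A1 (Homo sapiens), read by scintillation counting, with a stated time of 60 min, tested at 1 uM (a lower number here means less inhibition, a higher number more inhibition at the concentration tested (going by the name of the read-out)), compound 1 gives 0%, and in the same assay compound 2 gives 7%. Compound 2 carries the higher of the two numbers, but the gap to compound 1 lies within the usual scatter, so the two results cannot be told apart and the inhibition in this assay is level between them. Both show little inhibition at the concentration tested.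

Compound 3, `Nc1nc(N/N=C/c2ccc(-n3ccnc3)cc2)nc2c1ncn2[C@@H]1O[C@H](CO)[C@@H](O)[C@H]1O`, is not yet measured. It differs from compound 2 in one place: 1H-imidazol-1-yl in place of propoxy on an aromatic carbon. With both measured values close to zero and no step beyond the scatter shown between them, the account expects the change from compound 2 to compound 3 to produce no step beyond the scatter, a number 3 percentage points higher from compound 2 to compound 3 (within the scatter). Compound 3 is therefore estimated at 10%, with a range from 0% to 30%.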

Compound 3, a percentage reported as inhibition, at one concentration (the size of the read-out at that concentration, not a potency): 0%
Estimate against measurement, compound 3: 10 percentage points above; low and high end bracket the measured number.
By their numbers in this assay, from the lowest: compounds 1, 3 and 2 (each within the scatter of the next).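

Going by these compounds alone, the first step that can be read at this position comes with 1H-imidazol-1-yl in place of propoxy on an aromatic carbon, para to a large group: in this assay it is a number 7 percentage points lower from compound 2 to compound 3 (within the scatter). A five-membered aromatic ring and an open chain therefore cannot be told apart at this position, and the change from 4-propoxyphenyl to 4-(1H-imidazol-1-yl)phenyl leaves the inhibition level. Nothing available here speaks to why the two groups read alike.

With all three numbers close to zero, the compounds shown leave open whether any group at this position can lift inhibition beyond the scatter at the concentration tested. Whether an amine or a carboxylic acid on the same aromatic carbon, or a longer chain in place of propoxy, would do so remains unanswered.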